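A few compounds are considered here, and "the series" means these few. Any claim that something is new, unique, unknown or untested is made for them only; others in the source may bear on it.

Two compounds of a shared core were tested in a functional assay on MCF7 cells (Homo sapiens) for inhibition, read by MTT assay, with a stated time of 24 h, tested at 5 uM; on this read-out lower numbers stand for less inhibition of growth and higher numbers for more inhibition of growth at the one concentration tested. Compound 1 `CS(=O)(=O)c1ccc(-c2cnc3[nH]cc(-c4nnc(-c5ccncc5)o4)c(=O)c3c2)cc1` gives 2.35%, and compound 2 `CS(=O)(=O)c1ccc(-c2cnc3[nH]cc(-c4nnc(-c5ccc(Cl)cc5)o4)c(=O)c3c2)cc1` gives 0.86%. Going by the values given here, the one step measured so far, a number 1.5 percentage points lower from compound 1 to compound 2 (within the scatter), concerns the aromatic group on the oxadiazole, not the other end of the molecule. Compound 2 thus stands alongside compound 1, the two numbers lying within the scatter of each other, and neither can be called the more active.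

Compound 3 `N#Cc1ccc(-c2cnc3[nH]cc(-c4nnc(-c5ccc(Cl)cc5)o4)c(=O)c3c2)cc1` carries cyano in place of methylsulfonyl on an aromatic carbon. Among the compounds with values here, no measured step bears on this change, as the only step recorded touches a different part of the core. Nothing in the data therefore points to a movement beyond the scatter, and the step of a number 0.6 percentage points higher from compound 2 to compound 3 (within the scatter) is expected to stay within it. Compound 3 is accordingly estimated to give 1.5%, with a range from -8% to 11%.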

Compound 3, percent growth inhibition at one concentration: 4.65%
Beside the measured number, compound 3's estimate is 3.2 percentage points below it, within the range that was stated.
By their numbers in this assay, from the lowest: compounds 2, 1 and 3 (each within the scatter of the next).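

In this assay, the change from methylsulfonyl to cyano on an aromatic carbon, para to a large group, gives a number 3.8 percentage points higher from compound 2 to compound 3 (within the scatter), the first step measured at this end of the molecule. With 4-chlorophenyl held on the oxadiazole, the exchange of 4-(methylsulfonyl)phenyl for 4-cyanophenyl therefore does not separate compound 2 from compound 3, so a step at this position, like the earlier step on the oxadiazole, stays within the scatter. No measurement is available that would account for this result.

Going by these compounds, it remains open whether an amine, a carboxylic acid or a longer chain in this place on the ring would move the number beyond the scatter. Also open, on these data alone, is whether cyano would give a similar step with pyridin-4-yl on the oxadiazole.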